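This account rests on a few compounds, and the source may have more. Where it says the series, first, only, none or still open, it means among the compounds named here.

Measured in an assay on CHO cells for displacement of a labelled ligand from adenosine receptor A3 (Homo sapiens), read by scintillation counting, tested at 1 uM; on this read-out lower numbers stand for less inhibition and higher numbers for more inhibition at the one concentration tested (going by the name of the read-out):
compound 1 `CCc1nc(N)c2nn(-c3ccccc3)cc2n1` gives 38%
compound 2 `Nc1nc(CCc2ccccc2)nc2cn(-c3ccccc3)nc12` gives 17%
compound 3 `Nc1nc(CCc2ccc(O)cc2)nc2cn(-c3ccccc3)nc12` gives 37%

Compound 3 sits within the scatter of compound 1 and beyond the scatter above compound 2. Compound 4 `Nc1nc(CCCc2ccccc2)nc2cn(-c3ccccc3)nc12` differs from compound 3 by benzyl in place of 4-hydroxyphenyl on a saturated chain carbon, two bonds along the chain from an aromatic carbon. Among the compounds with values here, two measured steps bear on this. a number 20 percentage points higher from compound 2 to compound 3 (beyond the scatter) shows the hydroxy worth a modest gain, and a number 21 percentage points lower from compound 1 to compound 2 (beyond the scatter) shows the phenyl addition costing a modest amount, while a number 1 percentage points lower from compound 1 to compound 3 (within the scatter) stayed within the scatter. Within the data shown here, compound 4 lacks the hydroxy, as compound 2 does; the extra chain carbon has no measured precedent here. A modest drop in this assay is therefore expected, roughly reversing the hydroxy step. For compound 4 the estimate is 20%, with range 8% to 35%. The step of a number 17 percentage points lower from compound 3 to compound 4 (beyond the scatter) is thus expected.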

Compound 4, a percentage reported as inhibition, at one concentration (the size of the read-out at that concentration, not a potency): 12%
The estimate for compound 4 lay 8 percentage points above the measured number; measured number inside the range.
By their numbers in this assay, from the lowest: compounds 4 and 2 (each within the scatter of the next); then compounds 3 and 1 (each within the scatter of the next).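

In this assay, benzyl in place of phenyl at this place gives a number 5 percentage points lower from compound 2 to compound 4 (within the scatter), so the longer chain cannot be told apart from the shorter one. Benzyl in place of 4-hydroxyphenyl gives a number 25 percentage points lower from compound 3 to compound 4 (beyond the scatter) and benzyl in place of hydrogen gives a number 26 percentage points lower from compound 1 to compound 4 (beyond the scatter), so compound 4 shows the same modest loss as compound 2. No evidence on the cause accompanies these numbers. Open remain 4-hydroxybenzyl at this place, which would test the hydroxy on the longer chain, and an amine or a carboxylic acid in place of that hydroxy.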